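The compounds below may be only part of what the source reports. "The series", "measured", "known", "first", "only" and "open" are said of these compounds alone.

Compound 1, `Nc1nc(OCC(F)(F)F)c2ncn(/C=C3/CC3(CO)CO)c2n1`, was tested in an ADME assay on BCBL1 cells (Homo sapiens) for cytotoxicity, with a stated time of 7 days; on this read-out higher numbers stand for lower toxicity in this test and lower numbers for higher toxicity in this test. In this assay compound 1 reaches only a limit of the test, > 20000 nM, not a measured number. Two close relatives were tested as well. Compound 2, `Nc1nc2c(ncn2/C=C2/CC2(CO)CO)c(=O)[nH]1`, likewise gives only the limit, > 20000 nM. Compound 3, `CSc1nc(N)nc2c1ncn2/C=C1/CC1(CO)CO`, also gives a limit rather than a number, > 20000 nM. Compound 3 differs from compound 1 in a single place, and that step, a step that the two limits leave unreadable from compound 1 to compound 3, cannot be read in size since (the limit of > 20000 nM in this assay, at which 3 of the 3 values shown sit). Compound 4, `CCCCOc1nc(N)nc2c1ncn2/C=C1/CC1(CO)CO`, differs from compound 1 by propyl in place of trifluoromethyl on a saturated chain carbon bound to an oxygen on an aromatic ring. For the measured compounds named here, the only measured step that alters the 2,2,2-trifluoroethoxy group is the one to compound 3, and it tells nothing about size or direction, while all three measured compounds sit at the same limit. The change expected in this assay from compound 1 to compound 4 is therefore a step that the limit leaves unreadable from compound 1 to compound 4, that is, none beyond the scatter. Compound 4 is accordingly estimated at 30000 nM, within a range from 10000 nM to 100000 nM, and most likely it will again be reported only as the limit.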

Compound 4, half-maximal cytotoxic concentration: > 20000 nM
Compound 4: only a limit was reported (the forecaster's own chance of this, stated with the estimate: 80%); the middle value does not contradict the limit.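

In this assay compound 4 gives only the limit > 20000 nM and no measured number. Compound 1 and compound 3 also sit at a limit, so their steps to compound 4 cannot be read. The compounds shown leave open whether changing this group affects cytotoxicity at all.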